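Swapping Bromo for Methyl on the Phenoxy Ring

The compounds below may be only part of what the source reports. "The series", "measured", "known", "first", "only" and "open" are said of these compounds alone.

Within the data shown here, compound 3 `Cc1nn(C)c(Oc2ccc(Br)cc2)c1/C=N\OCc1c(Cl)c(-c2ccc(Cl)cc2)nn1C` gives 5960 nM in a functional assay on SGC-7901 cells (Homo sapiens) for antiproliferative activity, read by MTT assay, with a stated time of 72 h (on this read-out lower numbers stand for stronger inhibition and higher numbers for weaker inhibition), the second highest of the three numbers measured so far. Compound 2 `Cc1nn(C)c(Oc2ccc(Cl)cc2)c1/C=N\OCc1c(Cl)c(-c2ccc(Cl)cc2)nn1C` gives 7510 nM, and compound 1 `Cc1ccc(Oc2c(/C=N\OCc3c(Cl)c(-c4ccc(F)cc4)nn3C)c(C)nn2C)cc1` gives 4620 nM; all three lie within the scatter of one another. Compound 4 `Cc1ccc(Oc2c(/C=N\OCc3c(Cl)c(-c4ccc(Cl)cc4)nn3C)c(C)nn2C)cc1` differs from compound 3 by methyl in place of bromo on an aromatic carbon. Among the measured compounds shown here, the only measured step at this place is a 1.3-fold lower number from compound 2 to compound 3 (0.10 log units; within the scatter), which moved the number little. Compound 1 also carries the 4-methylphenoxy group, and its value sits among the others. Nothing here points to a step beyond the scatter. Compound 4 is therefore expected to give 5200 nM, between 2500 nM and 11000 nM. The expected step is a 1.1-fold lower number from compound 3 to compound 4 (0.06 log units; within the scatter), within the usual scatter.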

Compound 4, half-maximal inhibitory concentration: 3730 nM
Estimate against measurement, compound 4: 1.4-fold (0.14 log units) above, within the range that was stated.
By their numbers in this assay, from the lowest: compounds 4, 1, 3 and 2 (each within the scatter of the next).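

In this assay, 4-methylphenoxy, 4-bromophenoxy and 4-chlorophenoxy now read alike at this position, with every step inside the scatter (a 1.6-fold lower number from compound 3 to compound 4 (0.20 log units; within the scatter)) and (a 2.0-fold lower number from compound 2 to compound 4 (0.30 log units; within the scatter)). At the second place in these molecules, chloro in place of fluoro also stays inside the scatter (a 1.2-fold lower number from compound 1 to compound 4 (0.09 log units; within the scatter)). No measurement offered here explains these small differences. The compounds shown carry only small halogen or methyl groups at this position. As far as these compounds go, whether an amine, a carboxylic acid or a longer chain there would give a step beyond the scatter stays open.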